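The source may hold more compounds than are shown below. What is called first, only, known or untested is meant among the compounds shown, and "the series" means these compounds.

The measured compounds, with their results in a functional assay on MCF7 cells (Homo sapiens) for antiproliferative activity, read by sulforhodamine B assay, with a stated time of 48 h; a lower number here means a stronger inhibitor, a higher number a weaker inhibitor:

Compound 1 `CC(C)c1ccccc1OS(=O)(=O)c1cccc(NC(=O)C(C)(C)C)c1` gives 14000 nM in this assay.
Compound 2 `CC(=O)Nc1ccc(S(=O)(=O)Oc2ccccc2C(C)C)cc1` gives 16000 nM in this assay.
Compound 3 `CC(=O)Nc1ccc(S(=O)(=O)Oc2ccccc2I)cc1` gives 27000 nM in this assay.

Compound 3 has the highest of the three numbers, but its nearest neighbour is compound 2 and its furthest is compound 1, and both gaps lie within the scatter, so the three compounds cannot be told apart on these data. Among the compounds with values here, the one single-point step that is available, a 1.7-fold higher number from compound 2 to compound 3 (0.23 log units; within the scatter), concerns an aromatic substituent and does not touch the amide side of the molecule.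

Compound 4 `CCCCCC(=O)Nc1ccc(S(=O)(=O)Oc2ccccc2I)cc1` differs from compound 3 by butyl in place of hydrogen on a saturated chain carbon bound to a carbonyl carbon. Within the data shown here, no measured pair isolates a change of this kind: compound 1 carries a branched amide and compound 2 a plain acetamide, but they also differ elsewhere, so their values show only that both sit in the same region of this assay. Among the measured compounds shown here, with no step bearing directly on a longer amide chain, the expected step of a 1.4-fold lower number from compound 3 to compound 4 (0.13 log units; within the scatter) is small, with no direction supported beyond the scatter. Compound 4 is therefore estimated at 20000 nM, within a range of 7000 nM to 60000 nM.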

Compound 4, half-maximal inhibitory concentration: 10000 nM
The estimate for compound 4 lay 2.0-fold (0.30 log units) above the measured number; the range from low to high includes it.
By their numbers in this assay, from the lowest: compounds 4, 1, 2 and 3 (each within the scatter of the next, the first and the last beyond it).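

Replacing hydrogen with butyl on a saturated chain carbon bound to a carbonyl carbon, which turns acetamido into (pentylcarbonyl)amino, gives a 2.7-fold lower number from compound 3 to compound 4 (0.43 log units; beyond the scatter) in this assay. This is the only step among the compounds shown that lies beyond the scatter, so the amide chain is a place where the number in this assay responds, whereas the one earlier step, at the aromatic substituent, could not be told from the scatter. Nothing available on these compounds accounts for the change.

A single chain length at this position cannot show whether the trend continues, stops or reverses with an ethyl group, a longer chain such as octyl, or a chain ending in an amine or a carboxylic acid. As far as these compounds go, it also remains open whether butyl has the same effect when isopropyl stands in place of iodo.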